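A few compounds are considered here, and "the series" means these few. Any claim that something is new, unique, unknown or untested is made for them only; others in the source may bear on it.

The measured compounds and their numbers:

compound 1 `COc1cc(/C=C2\CN(C)C/C(=C\c3ccccc3F)C2=O)cc(OC)c1OC` 670 nM
compound 2 `CN1C/C(=C\c2cccc([N+](=O)[O-])c2)C(=O)/C(=C/c2ccccc2F)C1` 1080 nM
compound 3 `COc1cc(/C=C2\CN(C)C/C(=C\c3ccc(F)cc3)C2=O)cc(OC)c1OC` 7340 nM

In a functional assay on HepG2 cells (Homo sapiens) for cytotoxicity, read by MTT assay, with a stated time of 24 h (on this read-out higher numbers stand for weaker inhibition and lower numbers for stronger inhibition), compound 1 gives 670 nM, while compound 3 gives 7340 nM. The difference between them is 4-fluorophenyl in place of 2-fluorophenyl on a double-bonded chain carbon bound to a double-bonded ring carbon, and this change makes a step of an 11-fold higher number from compound 1 to compound 3 (1.04 log units; beyond the scatter). Compound 2 gives 1080 nM in this assay. The difference between the core of compound 2 and the core of compound 1 is not broken down here.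

Compound 4 `CN1C/C(=C\c2ccc(F)cc2)C(=O)/C(=C/c2cccc([N+](=O)[O-])c2)C1` has not yet been measured. It differs from compound 2 by 4-fluorophenyl in place of 2-fluorophenyl on a double-bonded chain carbon bound to a double-bonded ring carbon, the same change that separates compound 1 from compound 3 and in the same place. Because the step of an 11-fold higher number from compound 1 to compound 3 (1.04 log units; beyond the scatter) was large, the step from compound 2 to compound 4 is expected to be of a similar size, about an 8.3-fold higher number from compound 2 to compound 4 (0.92 log units; beyond the scatter), although it rests on a single pair and the core of compound 2 differs from that of compound 1. Compound 4 is therefore estimated at 9000 nM, with a range from 3000 nM to 30000 nM.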

Compound 4, half-maximal inhibitory concentration: 9340 nM
Compound 4: the middle estimate sits 1.0-fold (0.02 log units) below what was measured; the range from low to high includes it.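

In this assay, 4-fluorophenyl in place of 2-fluorophenyl on a double-bonded chain carbon bound to a double-bonded ring carbon again weakens inhibition, with a step of an 8.6-fold higher number from compound 2 to compound 4 (0.94 log units; beyond the scatter). Set beside the earlier step, the new one runs in the same direction and does not differ from it in size: the same change on two cores in this assay, an 11-fold higher number (1.04 log units; beyond the scatter) from compound 1 to compound 3 and an 8.6-fold higher number (0.94 log units; beyond the scatter) from compound 2 to compound 4, 1.3-fold (0.10 log units) apart, within the scatter of two such steps. Within this series the change therefore carried over from the core of compound 1 to the core of compound 2 with its size kept, but this rests on only two pairs in a single assay, so it neither establishes a rule for other cores nor gives any reason for the step.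

The compounds shown leave open whether the step would hold on a core bearing an amine or a carboxylic acid instead. They also leave open whether a chlorophenyl group or an unsubstituted phenyl group in place of the fluorophenyl groups would behave in the same way.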